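Quinoline amides: methylpiperazine replacing methylamino at the side chain

The source may report more compounds than this note shows. Statements on the series, on what has been measured and on what is new or still open speak of the compounds shown alone.

Compound 1 `Cc1nc2ccccc2c(-c2ccccc2)c1C(=O)N(C)Cc1cc(C(F)(F)F)cc(C(F)(F)F)c1` and compound 2 `CNCc1nc2ccccc2c(-c2ccccc2)c1C(=O)NCc1cc(C(F)(F)F)cc(C(F)(F)F)c1` share a core and were assayed in an in vitro assay on UC11MG cells for binding affinity to Substance-P receptor (Homo sapiens), read by radioligand binding; a higher number here means a weaker inhibitor, a lower number a stronger inhibitor. In this assay compound 1 gives 3.1 nM, while compound 2 gives 0.011 nM, the lower of the two numbers by a margin well beyond the scatter. Compound 3 `CN1CCN(Cc2nc3ccccc3c(-c3ccccc3)c2C(=O)NCc2cc(C(F)(F)F)cc(C(F)(F)F)c2)CC1` has not been measured; it differs from compound 2 by 4-methylpiperazin-1-yl in place of methylamino on a saturated chain carbon bound to an aromatic carbon. Within the data shown here, no measured pair shows this change, so the step is expected to be small to moderate, toward a higher number, from compound 2 to compound 3 a 4.5-fold higher number from compound 2 to compound 3 (0.66 log units; beyond the scatter). Compound 3 is expected to give 0.05 nM, within 0.01 nM to 0.3 nM.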

Compound 3, half-maximal inhibitory concentration: > 1000 nM
Compound 3 was reported as a limit; the forecaster's own chance of this, stated with the estimate: 5%; middle value at least 20000-fold (4.30 log units) away from the limit.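

Among these compounds, this step is the first reading of this position on its own, since compound 1 and compound 2 differ in more than one place. Placing 4-methylpiperazin-1-yl in place of methylamino on a saturated chain carbon bound to an aromatic carbon gives an at least 90000-fold higher number from compound 2 to compound 3 (4.95 log units; beyond the scatter), so an amine at this position does not by itself secure a low number. In this assay the figure for compound 3 is a limit, not a number: the limit of > 1000 nM in this assay, at which 1 of the 3 values shown sits.

Open, on these data alone, is whether the step follows the six-membered ring or the loss of the hydrogen-bond donor. A dimethylamino group or an open-chain ethylamino group would help separate the two.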